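This account rests on a few compounds, and the source may have more. Where it says the series, first, only, none or still open, it means among the compounds named here.

Compound 1 `Nc1ccc(-c2cn([C@@H]3CN[C@H](C(=O)Nc4ccc(Cl)c(C(F)(F)F)c4)C3)nn2)cn1` and compound 2 `CC(=O)Nc1ccc(-c2cn([C@@H]3CN[C@H](C(=O)Nc4ccc(Cl)c(C(F)(F)F)c4)C3)nn2)cn1` share one core and differ only by acetyl in place of hydrogen on a nitrogen on an aromatic ring. In a functional assay on K562 cells (Homo sapiens) for inhibition, read by MTT assay, with a stated time of 48 h (on this read-out lower numbers stand for stronger inhibition and higher numbers for weaker inhibition), compound 1 gives 10400 nM and compound 2 gives 8980 nM, so that change produced a 1.2-fold lower number from compound 1 to compound 2 (0.06 log units; within the scatter). Compound 3 `Nc1n[nH]c2cc(-c3cn([C@@H]4CN[C@H](C(=O)Nc5ccc(Cl)cc5Cl)C4)nn3)ccc12` is built on a different core, and the difference between the two cores is not broken down here. In this assay compound 3 gives 28400 nM, the highest of the three numbers. Compound 4 `CC(=O)Nc1n[nH]c2cc(-c3cn([C@@H]4CN[C@H](C(=O)Nc5ccc(Cl)cc5Cl)C4)nn3)ccc12` has not yet been measured; it differs from compound 3 by acetyl in place of hydrogen on a nitrogen on an aromatic ring, the same change that turns compound 1 into compound 2, at a place described in the same words. Because a 1.2-fold lower number from compound 1 to compound 2 (0.06 log units; within the scatter) stayed within the scatter, the step from compound 3 to compound 4 is expected to be of similar size, a 1.2-fold lower number from compound 3 to compound 4 (0.07 log units; within the scatter). That expectation rests on a single earlier instance, observed on another core, so it is held loosely and a wide range is allowed. Compound 4 is estimated at 24000 nM, between 12000 nM and 50000 nM.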

Compound 4, half-maximal inhibitory concentration: 2090 nM
For compound 4 the middle estimate is 11-fold (1.06 log units) above the measured one; the whole stated range lies above it.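

In this assay, putting acetyl in place of hydrogen on a nitrogen on an aromatic ring, the change from amino to acetamido, gave a 14-fold lower number from compound 3 to compound 4 (1.13 log units; beyond the scatter), and this differs clearly from the result of the same change on the other core: the same change on two cores in this assay, a 1.2-fold lower number (0.06 log units; within the scatter) from compound 1 to compound 2 and a 14-fold lower number (1.13 log units; beyond the scatter) from compound 3 to compound 4, 12-fold (1.07 log units) apart, beyond the scatter of two such steps

So, for these two pairs, the effect of this change did not carry from one core to the other, and a small step on the core of compound 1 gave no guide to the large step on the core of compound 3. This does not show which part of the difference between the two cores matters, nor why the steps differ, and two pairs give no general rule for the series.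

The compounds shown leave open whether a longer chain such as propanoyl, or a methanesulfonyl group, on the same nitrogen would match acetyl on the core of compound 3. They also leave open how the amino to acetamido change behaves on a core that carries only part of the difference between these two.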